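The source may hold more compounds than are shown below. What is called first, only, known or untested is meant among the compounds shown, and "the series" means these compounds.

Measured compounds:
- compound 1 `COCOc1cc(/C=C/C(=O)OCC(=O)Nc2ccc(Cl)cc2)ccc1OCc1ccccc1`: > 200000 nM
- compound 2 `COCOc1cc(/C=C/C(=O)OCC(=O)NN2CCOCC2)ccc1OCc1ccccc1`: > 200000 nM
- compound 3 `O=C(COC(=O)/C=C/c1ccc(O)c(O)c1)NN1CCOCC1`: > 200000 nM

In a functional assay on LS174T cells (Homo sapiens) for cytotoxicity, read by MTT assay, with a stated time of 72 h (a lower number here means a stronger inhibitor, a higher number a weaker inhibitor), compound 1 gives > 200000 nM, a limit of the assay and not a number. Compound 2 likewise gives > 200000 nM, again a limit. Compound 3 gives > 200000 nM, a limit as well. The change from compound 2 to compound 1 is 4-chlorophenyl in place of morpholin-4-yl on an amide-type nitrogen; its size is a step that the two limits leave unreadable from compound 2 to compound 1. The difference between the cores of compound 2 and compound 3 is not broken down here. The unmeasured compound 4 `O=C(COC(=O)/C=C/c1ccc(O)c(O)c1)Nc1ccc(Cl)cc1` carries the same change on the core of compound 3: 4-chlorophenyl in place of morpholin-4-yl on an amide-type nitrogen.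

For compound 4 the expected step is a number no higher from compound 3 to compound 4 (the limit leaves the size open), resting on the limit of > 200000 nM in this assay, at which 3 of the 3 values shown sit, and on the unreadable a step that the two limits leave unreadable from compound 2 to compound 1. The estimate for compound 4 in this assay is 200000 nM, with a range of 50000 nM to 400000 nM.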

Compound 4, half-maximal inhibitory concentration: 108000 nM
Compound 4: middle estimate off by 1.9-fold (0.27 log units), on the high side; low and high end bracket the measured number.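

In this assay, 4-chlorophenyl in place of morpholin-4-yl on an amide-type nitrogen gives an at least 1.8-fold lower number from compound 3 to compound 4 (0.26 log units; that floor lies within the scatter) on the core of compound 3. The same change on the core of compound 2 leads to compound 1, but that step cannot be read, so the sizes on the two cores cannot be compared. The result therefore neither shows that the change carries from one core to the other nor rules it out, and the comparison is limited by how many values are not numbers: the limit of > 200000 nM in this assay, at which 3 of the 4 values shown sit.

From the compounds shown here alone, what an amine or a carboxylic acid in place of the 4-chlorophenyl would do on the amide-type nitrogen remains open. So does the effect of a longer chain there.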